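The source may hold more compounds than are shown below. What is called first, only, known or untested is meant among the compounds shown, and "the series" means these compounds.

Measured so far:

Compound 1 `NC(=O)c1c(NC(=O)c2ccc(C(F)(F)F)cc2)sc2c1CCN(Cc1ccc(Cl)cc1)C2` — in a functional assay on MKN-74 cells (Homo sapiens) for antiproliferative activity, with a stated time of 24 h (on this read-out higher numbers stand for weaker inhibition and lower numbers for stronger inhibition), compound 1 gives > 50000 nM, which is a limit of the assay and not a number.

Compound 2 `NC(=O)c1c(NC(=O)c2cccc([N+](=O)[O-])c2)sc2c1CCN(Cc1c(Cl)cccc1Cl)C2` — in this assay compound 2 gives 13500 nM.

Compound 3 `NC(=O)c1c(NC(=O)c2ccccc2Cl)sc2c1CCN(C(=S)Nc1ccccc1)C2` — in this assay compound 3 gives 15600 nM.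

Only two of the three results are numbers. Compound 3 supplies one of them, and compound 2 the other, with a gap between them that sits within the usual scatter, so the two compounds cannot be told apart on these data. Compound 1 stands apart only in that its result is a limit.

Compound 4 `NC(=O)c1c(NC(=O)c2ccccc2Cl)sc2c1CCN(C(=S)Nc1cccnc1)C2` has not yet been measured. It differs from compound 3 in one place: pyridin-3-yl in place of phenyl on an amide-type nitrogen. Among the compounds with values here, no pair of measured compounds differs in the same way, so there is no measured step to lean on. A change of this kind is expected to move the result little, if at all, and the step from compound 3 to compound 4 is estimated at a 1.2-fold higher number from compound 3 to compound 4 (0.06 log units; within the scatter), likely no further than the scatter. For compound 4 the expected result in this assay is 18000 nM, with a range from 7000 nM to 45000 nM.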

Compound 4, half-maximal inhibitory concentration: 38600 nM
Compound 4: middle estimate off by 2.1-fold (0.33 log units), on the low side, within the range that was stated.
By their numbers in this assay, from the lowest: compounds 2 and 3 (each within the scatter of the next); then compound 4. At a limit, above all of these: compound 1.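

Within the data shown here, compound 3 and compound 4 give the first single change that can be read here: in this assay, pyridin-3-yl in place of phenyl on the amide-type nitrogen gives a 2.5-fold higher number from compound 3 to compound 4 (0.39 log units; beyond the scatter). This position is therefore not indifferent to a small edit, as the ring keeps its size and a single ring carbon gives way to nitrogen, yet inhibition weakens modestly. Compound 1 shows where the read-out ends, and its result is a limit and not a number: the limit of > 50000 nM in this assay, at which 1 of the 4 values shown sits.

On these data alone, what pyridin-4-yl or a saturated ring such as cyclohexyl would do on this nitrogen remains open. Also open, as far as these compounds go, is whether the same swap would give a similar step in compounds that differ from these two elsewhere on the shared core.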